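A few compounds are considered here, and "the series" means these few. Any claim that something is new, unique, unknown or untested is made for them only; others in the source may bear on it.

The series shares one core; compound 1 is `Cc1ccc(NC(=O)N[C@H](C)c2ccccc2)cc1`, compound 2 is `CC(=O)c1ccc(NC(=O)N[C@H](C)c2ccccc2)cc1`, compound 3 is `C[C@@H](NC(=O)Nc1ccc(F)cc1)c1ccccc1`, and the still unmeasured compound 4 is `C[C@@H](NC(=O)Nc1ccc(Br)cc1)c1ccccc1`. In an ADME assay on the whole organism with Oryza sativa as the target, tested at 10 uM (on this read-out higher numbers stand for a weaker effect at the one concentration tested and lower numbers for a stronger effect), compound 1 gives 64%, compound 2 gives 84% and compound 3 gives 92%. Compound 3 thus stands at the top of the three numbers, though its gap to compound 2 lies within the scatter and only its gap to compound 1 is beyond it. The measured steps are a number 20 percentage points higher from compound 1 to compound 2 (beyond the scatter), a number 28 percentage points higher from compound 1 to compound 3 (beyond the scatter) and a number 8 percentage points higher from compound 2 to compound 3 (within the scatter). The change to compound 4 is bromo in place of fluoro on an aromatic carbon. Among the measured compounds shown here, no measured step exchanges one halogen for another, so the closest guide is the small a number 8 percentage points higher from compound 2 to compound 3 (within the scatter) set against the larger a number 28 percentage points higher from compound 1 to compound 3 (beyond the scatter), and because compound 3 already gives 92% there is little room left upward in this assay. A step of a number 2 percentage points lower from compound 3 to compound 4 (within the scatter) is therefore expected, within the scatter. For compound 4 the expected value in this assay is 90%, with a range from 78% to 99%.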

Compound 4, a percentage reported as activity, at one concentration (the size of the read-out at that concentration, not a potency): 87%
Compound 4: middle estimate off by 3 percentage points, on the high side; the measured number falls inside the stated range.
By their numbers in this assay, from the lowest: compound 1; then compounds 2, 4 and 3 (each within the scatter of the next).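

In this assay, the exchange of one halogen for another on an aromatic carbon para to a large group gives a number 5 percentage points lower from compound 3 to compound 4 (within the scatter) and so does not separate bromo from fluoro. Bromo also stays unresolved from acetyl, with a number 3 percentage points higher from compound 2 to compound 4 (within the scatter) on record, whereas a number 23 percentage points higher from compound 1 to compound 4 (beyond the scatter) adds a third comparison in which methyl stands apart, now against bromo as well as acetyl and fluoro. No data on hand bear on why methyl differs from the other three groups.

Open, going by these compounds, is whether the lower number is specific to methyl or also extends to an ethyl group or a longer chain at this place. Also open, on these data alone, is how chloro, methoxy, an amine or a carboxylic acid would read here.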